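Chloro in place of azido on the chain of compound 2

The source may report more compounds than this note shows. Statements on the series, on what has been measured and on what is new or still open speak of the compounds shown alone.

In a functional assay on HCT-116 cells (Homo sapiens) for antiproliferative activity, read by MTT assay, with a stated time of 48 h (a higher number here means a weaker inhibitor, a lower number a stronger inhibitor), compound 1 (`CCCCCCCCCC(CCOS(C)(=O)=O)n1cnc2c(Cl)ncnc21`) gives 5440 nM, compound 2 (`CCCCCCCCCC(CCN=[N+]=[N-])n1cnc2c(Cl)ncnc21`) gives 1040 nM and compound 3 (`CCCCCCCCC[C@H](CCN=[N+]=[N-])n1cnc2c(Cl)ncnc21`) gives 1190 nM. Compound 2 therefore stands at the low end of these numbers, level with compound 3, while compound 1 stands clearly higher.

The open structure is compound 4 (`CCCCCCCCCC(CCCl)n1cnc2c(Cl)ncnc21`), which carries chloro in place of azido on a saturated chain carbon, three bonds along the chain from an aromatic nitrogen.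

Within the data shown here, two measured steps bear on this. Among the measured compounds shown here, the only step that exchanges a group at this place is a 5.2-fold lower number from compound 1 to compound 2 (0.72 log units; beyond the scatter), so such an exchange has moved the number beyond the scatter once. The other step, a 1.1-fold higher number from compound 2 to compound 3 (0.06 log units; within the scatter), involves only the fact that one of compounds 2 and 3 is drawn with a defined configuration and the other without, at the place where they differ and leaves the azido group in place, so it sets the level of compound 2 rather than the size of the change.

For the measured compounds named here, no measured compound carries chloro at this place, so the direction is tentative. Going by the values given here, compound 1, the only other group tested here, gives the higher 5440 nM, so a modest move towards a higher number is expected. The estimated change is a 1.9-fold higher number from compound 2 to compound 4 (0.28 log units; within the scatter). For compound 4 the expected value is 2000 nM, with an estimated range of 800 nM to 5500 nM.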

Compound 4, half-maximal inhibitory concentration: 10200 nM
Compound 4: middle estimate off by 5.1-fold (0.71 log units), on the low side; measured number outside the range, above it.
By their numbers in this assay, from the lowest: compounds 2 and 3 (each within the scatter of the next); then compounds 1 and 4 (each within the scatter of the next).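

In this assay the exchange of azido for chloro on a saturated chain carbon, three bonds along the chain from an aromatic nitrogen, gives a 9.8-fold higher number from compound 2 to compound 4 (0.99 log units; beyond the scatter) and so shows that the number can also rise beyond the scatter on leaving azido for a group other than (methylsulfonyl)oxy. Chloro in place of (methylsulfonyl)oxy gives a 1.9-fold higher number from compound 1 to compound 4 (0.27 log units; within the scatter) and so puts these two groups level, which leaves azido, carried by compound 2 and compound 3, as the one group of the three that goes with the lower numbers. The supporting information at hand concerns only drawn configuration and does not bear on this exchange.

On these data alone, it remains open whether the lower numbers belong to azido alone or extend to other groups at this place, such as an amine or a hydroxyl, and whether those groups would fall with azido or with chloro and (methylsulfonyl)oxy. As far as these compounds go, it is also open whether the same order of groups would hold on a shorter chain.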